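The source may hold more compounds than are shown below. What is called first, only, known or untested is meant among the compounds shown, and "the series" means these compounds.

Measured compounds in this series:

Compound 1 `CCC/C=C/C(=O)Nc1cccc(Oc2nc(Nc3cccc(C#N)c3)nc3c2CSCC3)c1` with 7220 nM
Compound 2 `CC(C)=CC(=O)Nc1cccc(Oc2nc(Nc3cccc(C#N)c3)nc3c2CSCC3)c1` with 29200 nM
Compound 3 `CCC/C=C/C(=O)Nc1cccc(Oc2nc(Nc3ccc(OC)cc3)nc3c2CSCC3)c1` with 12800 nM

All values come from a functional assay on HeLa cells (Homo sapiens) for antiproliferative activity, read by MTT assay, with a stated time of 72 h; a lower number here means a stronger inhibitor, a higher number a weaker inhibitor. Compound 1 and compound 3 share the amide side chain and differ only in the group on the nitrogen on the aromatic ring: 4-methoxyphenyl in place of 3-cyanophenyl on a nitrogen on an aromatic ring. The resulting step, a 1.8-fold higher number from compound 1 to compound 3 (0.25 log units; within the scatter), leaves the two compounds within the scatter of each other, so no order between them is claimed.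

Compound 2 is obtained from compound 1 by one change at the carbonyl carbon: 2-methylprop-1-en-1-yl in place of pent-1-en-1-yl on a carbonyl carbon. This step, a 4.0-fold higher number from compound 1 to compound 2 (0.61 log units; beyond the scatter), is modest but beyond the scatter, with compound 2 giving the weaker inhibition of the pair.

Compound 4 `COc1ccc(Nc2nc3c(c(Oc4cccc(NC(=O)C=C(C)C)c4)n2)CSCC3)cc1` has not yet been measured in this assay. It stands to compound 3 as compound 2 stands to compound 1: 2-methylprop-1-en-1-yl in place of pent-1-en-1-yl on a carbonyl carbon. The place is described in the same words for both pairs, so this is the same change made on the other core. Among the compounds with values here, with only one measured instance of the change, the expectation rests on compound 1 and compound 2 alone, because a 4.0-fold higher number from compound 1 to compound 2 (0.61 log units; beyond the scatter) is the sole precedent. Compound 4 is therefore expected to show a step of about a 3.9-fold higher number from compound 3 to compound 4 (0.59 log units; beyond the scatter) from compound 3, on the assumption that the core difference does not alter the response to the side-chain change. The estimate for compound 4 in this assay is 50000 nM, with a plausible range from 20000 nM to 130000 nM; this is an expectation, not a measurement, and a single precedent gives it wide uncertainty.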

Compound 4, half-maximal inhibitory concentration: 19100 nM
For compound 4 the middle estimate is 2.6-fold (0.42 log units) above the measured one; measured number outside the range, below it.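

Carried onto the core of compound 3, 2-methylprop-1-en-1-yl in place of pent-1-en-1-yl on the carbonyl carbon gives a 1.5-fold higher number from compound 3 to compound 4 (0.17 log units; within the scatter), so in this assay the step seen on the core of compound 1 does not recur at the same size: the same change on two cores in this assay, a 4.0-fold higher number (0.61 log units; beyond the scatter) from compound 1 to compound 2 and a 1.5-fold higher number (0.17 log units; within the scatter) from compound 3 to compound 4, 2.7-fold (0.43 log units) apart, beyond the scatter of two such steps. The other edge of the same set, 4-methoxyphenyl in place of 3-cyanophenyl on the nitrogen, gives a 1.5-fold lower number from compound 2 to compound 4 (0.18 log units; within the scatter), and it too stands apart from its counterpart: the same change on two cores in this assay, a 1.8-fold higher number (0.25 log units; within the scatter) from compound 1 to compound 3 and a 1.5-fold lower number (0.18 log units; within the scatter) from compound 2 to compound 4, 2.7-fold (0.43 log units) apart, beyond the scatter of two such steps. Across these four compounds, then, the side-chain step does not carry over unchanged in size from one core to the other, but a single comparison of this kind does not show why, nor whether the same mismatch would appear with other amide side chains or other groups on the nitrogen.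

Still open, from the compounds shown here alone, is how the series responds to an amide side chain without the double bond, such as a saturated pentyl chain, or to one carrying a dimethylamino group. Also open, going by these compounds, is whether a nitrogen substituent such as 4-chlorophenyl would follow the behaviour of the 3-cyanophenyl pair or that of the 4-methoxyphenyl pair.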